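Ethynyl in place of the branched alkenyl amide

The source may report more compounds than this note shows. Statements on the series, on what has been measured and on what is new or still open speak of the compounds shown alone.

Compound 1 `C/C=C/C(=O)Nc1ccc(CCCCCC)cc1`: > 100000 nM
Compound 2 `CCCCCCc1ccc(NC(=O)C=C(C)C)cc1`: > 100000 nM

In an in vitro assay on BL21-DE3 cells for displacement of a labelled ligand from thyroid hormone receptor beta (Homo sapiens), read by fluorescence polarization (on this read-out higher numbers stand for weaker inhibition and lower numbers for stronger inhibition), compound 1 reaches only the limit of the assay, > 100000 nM. In this assay compound 2 likewise gives no number but the limit > 100000 nM. The step that the two limits leave unreadable from compound 1 to compound 2 therefore cannot be read, and both values sit at the limit of > 100000 nM in this assay, at which 2 of the 2 values shown sit.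

Compound 3 `C#CC(=O)Nc1ccc(CCCCCC)cc1` is not yet measured. It differs from compound 2 in one place: ethynyl in place of 2-methylprop-1-en-1-yl on a carbonyl carbon. Among the compounds with values here, the only measured step, from compound 1 to compound 2, bears on the same carbonyl carbon but gives no readable size, so it offers no direction for the new change. With two limits and nothing else, compound 3 is expected to stay near the limit as well. The step that the limit leaves unreadable from compound 2 to compound 3 is thus estimated to be none beyond the scatter. In this assay compound 3 is expected to give about 150000 nM, within a range from 30000 nM to 1000000 nM.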

Compound 3, half-maximal inhibitory concentration: 35100 nM
Beside the measured number, compound 3's estimate is 4.3-fold (0.63 log units) above it; the range from low to high includes it.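

With ethynyl on the carbonyl carbon, the series gives its first readable number in this assay: ethynyl in place of 2-methylprop-1-en-1-yl gives an at least 2.8-fold lower number from compound 2 to compound 3 (0.45 log units; beyond the scatter), and ethynyl in place of prop-1-en-1-yl gives an at least 2.8-fold lower number from compound 1 to compound 3 (0.45 log units; beyond the scatter). This shows that the group on this carbonyl carbon can shift the read-out, which the two alkenyl amides alone could not show. Both sizes are only lower bounds, and the step between the two alkenyl amides cannot be read, since those two compounds rest on a limit rather than a number: the limit of > 100000 nM in this assay, at which 2 of the 3 values shown sit.

The compounds shown leave open whether the triple bond or the shorter group goes with the change, which an ethyl group on the same carbonyl carbon would help to separate. On these data alone, how a prop-1-yn-1-yl group would read there also remains open.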